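Hydroxyphenyl placement on the shared core, thiophene series

The source may hold more compounds than are shown below. What is called first, only, known or untested is meant among the compounds shown, and "the series" means these compounds.

Measured compounds:
- compound 1, `Oc1ccc(-c2cc(-c3ccc(Cl)cc3)nc(-c3cccnc3)c2)cc1`: 18.8%
- compound 2, `Oc1cccc(-c2cc(-c3ccc(Cl)cc3)nc(-c3cccs3)c2)c1`: 15.1%

In an assay on isolated protein for inhibition of DNA topoisomerase 1 (Homo sapiens), with a stated time of 30 min, tested at 100 uM (a higher number here means a stronger effect of the compound at the concentration tested, a lower number a weaker effect), compound 1 gives 18.8% and compound 2 gives 15.1%. Among the compounds with values here, compound 2 cannot be set apart from compound 1 on these numbers: the gap between the two lies within the scatter, and since the two compounds differ in more than one place no single step between them can be stated. Both numbers are modest for this assay.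

Compound 3, `Oc1ccc(-c2cc(-c3ccc(Cl)cc3)nc(-c3cccs3)c2)cc1`, has not yet been measured. It differs from compound 2 in one place only, computed as 4-hydroxyphenyl in place of 3-hydroxyphenyl on an aromatic carbon, the change sitting on an aromatic carbon of a six-membered aromatic ring with 1 nitrogen, opposite the ring nitrogen. Compound 3 thus carries the same hydroxyphenyl as compound 1 and the same thiophen-2-yl as compound 2. Nothing in the measured pair points in a direction for this change: the two values at hand sit within the scatter of each other. The step from compound 2 to compound 3 is therefore expected to be small, within the scatter, as a number 1.9 percentage points higher from compound 2 to compound 3 (within the scatter), in either direction. For compound 3 the expected value in this assay is 17%, with a range from 5% to 30%.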

Compound 3, a percentage reported as inhibition, at one concentration (the size of the read-out at that concentration, not a potency): 38.8%
Estimate against measurement, compound 3: 21.8 percentage points below, and the stated range ends below it.
By their numbers in this assay, from the lowest: compounds 2 and 1 (each within the scatter of the next); then compound 3.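

In this assay, 4-hydroxyphenyl in place of 3-hydroxyphenyl on the aromatic carbon opposite the ring nitrogen gives a number 23.7 percentage points higher from compound 2 to compound 3 (beyond the scatter) and shows that, with thiophen-2-yl on the shared core, the placement of the hydroxyl on this phenyl matters, which the earlier pair, differing in more than one place, could not show. With 4-hydroxyphenyl held fixed, thiophen-2-yl in place of pyridin-3-yl gives a number 20 percentage points higher from compound 1 to compound 3 (beyond the scatter) and so shows that the group at the other position matters too, with compound 3 standing apart from both earlier compounds, although compound 3 at 38.8% remains a read-out at one concentration and not a potency. No measurement at hand bears on what lies behind either step.

Open, as far as these compounds go, is whether the placement step carries over to the core with pyridin-3-yl in place of thiophen-2-yl. Also open, from the compounds shown here alone, is what a methoxy group, an amine or a carboxylic acid would give in place of the hydroxyl on the 4-hydroxyphenyl group.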